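Thiazole amide in place of cyanophenyl on an inactive series

The source may report more compounds than this note shows. Statements on the series, on what has been measured and on what is new or still open speak of the compounds shown alone.

Compound 1 `O=C(C1CC12CCC2)N1CCc2nc(C#Cc3ccccc3)sc2C1`: a limit, > 10000 nM
Compound 2 `O=C(C1CCC(F)(F)CC1)N1CCc2nc(C#Cc3ccccc3)sc2C1`: a limit, > 10000 nM
Compound 3 `N#Cc1cccc(C(=O)N2CCc3nc(C#Cc4ccccc4)sc3C2)c1`: a limit, > 10000 nM

All three values come from an assay on HEK293 cells for negative allosteric modulation of metabotropic glutamate receptor 5 (Homo sapiens), read by FLIPR, with a stated time of 1 h (a lower number here means a stronger inhibitor, a higher number a weaker inhibitor), and each is a limit rather than a measured number: the limit of > 10000 nM in this assay, at which 3 of the 3 values shown sit. Compound 3 thus stands only at a limit, as do its two neighbours. Since both ends of every pair sit at the limit, the steps a step that the two limits leave unreadable from compound 1 to compound 2, a step that the two limits leave unreadable from compound 1 to compound 3 and a step that the two limits leave unreadable from compound 2 to compound 3 have no readable size or direction. Compound 4 `Cc1nc(C(=O)N2CCc3nc(C#Cc4ccccc4)sc3C2)cs1` differs from compound 3 by 2-methyl-1,3-thiazol-4-yl in place of 3-cyanophenyl on a carbonyl carbon. Among the measured compounds shown here, no measured step offers a usable size, so the expectation for this assay rests only on all three values being limits. Compound 4 is expected to stay near that limit, with an estimated step that the limit leaves unreadable from compound 3 to compound 4. The estimate for compound 4 is 15000 nM, between 2000 nM and 100000 nM.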

Compound 4, half-maximal inhibitory concentration: > 10000 nM
Compound 4 was reported as a limit (the forecaster's own chance of this, stated with the estimate: 70%); the middle value lies beyond the limit too.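

Compound 4 is reported only as a limit, like compound 1, compound 2 and compound 3, so no step among these four can be read: the limit of > 10000 nM in this assay, at which 4 of the 4 values shown sit.

The compounds shown leave open which of the four, if any, is the stronger inhibitor in this assay.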